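This account rests on a few compounds, and the source may have more. Where it says the series, first, only, none or still open, it means among the compounds named here.

Measured so far in a toxicity assay on Huh-7 cells (Homo sapiens) for cytotoxicity, with a stated time of 3 days; a higher number here means that more compound is tolerated, a lower number that less compound is tolerated:
- compound 1 `C[C@@]1(O)[C@H](O)[C@@H](CO)O[C@H]1n1cc(I)c2c(N)ncnc21`: 19800 nM
- compound 2 `Nc1ncnc2c1c(-c1cccs1)cn2[C@H]1C[C@H](O)[C@@H](CO)O1`: > 44000 nM

Compound 1 gives a number in this assay. For compound 2 the reading is a limit of the assay and not a number, namely (the limit of > 44000 nM in this assay, at which 1 of the 2 values shown sits). Where compound 2 stands on the numbers shown is therefore known only as that limit, with nothing on how far past it the compound lies.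

Compound 3 `Nc1ncnc2c1c(-c1ccsc1)cn2[C@H]1C[C@H](O)[C@@H](CO)O1` is not yet measured in this assay. It differs from compound 2 in one place: thiophen-3-yl in place of thiophen-2-yl on an aromatic carbon. The two have the same atoms, joined differently, and the ring that leaves and the ring that enters match in every count given. Among the measured compounds shown here, no step between two measured compounds of this kind is available, so nothing here shows what such a change does in this assay. The expectation is a step of no size beyond the usual scatter, in no set direction. The estimate for compound 3 in this assay is 50000 nM, within 25000 nM to 100000 nM. The step this estimate means is expected to be a step that the limit leaves unreadable from compound 2 to compound 3, within the scatter. Compound 3 is expected, more likely than not, to be reported again only as a limit.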

Compound 3, half-maximal cytotoxic concentration: > 44000 nM
Compound 3 gave a limit, no number (the forecaster's own chance of this, stated with the estimate: 70%); the middle value lies beyond the limit too.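

Compound 2 and compound 3 are both reported only as limits and not as numbers, so no step between them can be read: the limit of > 44000 nM in this assay, at which 2 of the 3 values shown sit.

Going by these compounds, how far either compound lies past that limit stays open, and so does whether thiophen-3-yl in place of thiophen-2-yl makes any difference to how much compound is tolerated.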